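The compounds below may be only part of what the source reports. "The series", "measured", "known", "first", "only" and "open" are said of these compounds alone.

Measured so far:
compound 1 `O=C(O)c1ccc(NC(=O)[C@@H]2CC(O)CN2S(=O)(=O)c2ccccc2)cc1` gives 33.9% in a functional assay on the whole organism for inhibition, with Rattus norvegicus as the target, read by paw edema, with stated times of 1 h and 0.5 h, at a dose of 100 mg/kg by the oral route; a lower number here means less inhibition, a higher number more inhibition at the dose given (going by the name of the read-out)
compound 2 `Cc1ccccc1S(=O)(=O)N1CCC[C@H]1C(=O)Nc1ccc(C(=O)O)cc1` gives 35.8% in this assay

Compound 2 holds the highest of the two numbers, yet its gap to compound 1 lies within the scatter, so no order between them can be claimed. Compound 3 `O=C(O)c1ccc(NC(=O)[C@@H]2CCCN2S(=O)(=O)c2ccccc2)cc1` differs from compound 2 in one place: hydrogen in place of methyl on an aromatic carbon. Within the data shown here, no step between measured compounds is available to guide the outcome, so no shift beyond the scatter is expected, and the estimated step from compound 2 to compound 3 is a number 2.8 percentage points lower from compound 2 to compound 3 (within the scatter). Compound 3 is therefore expected to give about 33% in this assay, within a range from 20% to 46%.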

Compound 3, a percentage reported as inhibition, in the whole organism at one dose (the size of the read-out at that dose, not a potency): 23.6%
For compound 3 the middle estimate is 9.4 percentage points above the measured one; the range from low to high includes it.
By their numbers in this assay, from the lowest: compound 3; then compounds 1 and 2 (each within the scatter of the next).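

In this assay, the phenyl compound falls behind its 2-methylphenyl partner, with the loss of the methyl on the aromatic carbon ortho to a large group giving a number 12.2 percentage points lower from compound 2 to compound 3 (beyond the scatter). Hydrogen in place of hydroxy on the saturated ring carbon gives a number 10.3 percentage points lower from compound 1 to compound 3 (beyond the scatter), so each of these two single groups separately marks a higher number than the unsubstituted compound 3. Nothing available explains either step. Going by these compounds, whether an ethyl or methoxy group on that aromatic carbon, or an amine on the saturated ring carbon, would keep the higher number remains open. So does the outcome of carrying the methyl and the hydroxy together.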